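Extending an amide chain by one carbon

This account rests on a few compounds, and the source may have more. Where it says the series, first, only, none or still open, it means among the compounds named here.

Measured so far:
Compound 1, `CCCC(=O)Nc1ccc2[nH]cc(C3CCN(C)CC3)c2n1`: 6.9 nM
Compound 2, `CCCCC(=O)Nc1ccc2[nH]cc(C3CCN(C)CC3)c2n1`: 14 nM
Compound 3, `CC(=O)Nc1ccc2[nH]cc(C3CCNCC3)c2n1`: 45 nM

All three were tested in an assay for binding affinity to 5-hydroxytryptamine receptor 1F (Homo sapiens), read by radioligand binding; a lower number here means a stronger inhibitor, a higher number a weaker inhibitor. Compound 1 gives the lowest number of the three. Compound 2 differs from it by methyl in place of hydrogen on a saturated chain carbon, three bonds along the chain from a carbonyl carbon, and that change gave a 2.0-fold higher number from compound 1 to compound 2 (0.31 log units; beyond the scatter). Compound 3 stands highest of the three; how its core differs from the core of compound 1 is not broken down here.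

Compound 4, `CCC(=O)Nc1ccc2[nH]cc(C3CCNCC3)c2n1`, has not yet been measured. It differs from compound 3 by methyl in place of hydrogen on a saturated chain carbon bound to a carbonyl carbon. Going by the values given here, this is the same kind of change as the one from compound 1 to compound 2, but not the same: there the added methyl sat on a saturated chain carbon three bonds along the chain from a carbonyl carbon, whereas here it sits on a saturated chain carbon bound to a carbonyl carbon. Read one bond further out, the change turns acetamido into propanoylamino.

Among the compounds with values here, the only measured step of this kind raised the number, as a 2.0-fold higher number from compound 1 to compound 2 (0.31 log units; beyond the scatter) shows, yet the compound with the longer chain and the lowest number, compound 1, gives 6.9 nM, while compound 3 with the shortest chain gives 45 nM. The step from compound 3 to compound 4 in this assay is therefore expected to be small, estimated at a 1.5-fold lower number from compound 3 to compound 4 (0.18 log units; within the scatter). Compound 4 is expected to give about 30 nM, most likely between 10 nM and 90 nM.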

Compound 4, inhibition constant: 35 nM
For compound 4 the middle estimate is 1.2-fold (0.07 log units) below the measured one; measured number inside the range.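

In this assay, adding a methyl to the saturated chain carbon bound to a carbonyl carbon turns acetamido into propanoylamino and gives a 1.3-fold lower number from compound 3 to compound 4 (0.11 log units; within the scatter), so this step cannot be told apart from no effect. Set beside the earlier step on the other core, the two results do not differ by more than repeated measurements of such steps can: the same change on two cores in this assay, a 2.0-fold higher number (0.31 log units; beyond the scatter) from compound 1 to compound 2 and a 1.3-fold lower number (0.11 log units; within the scatter) from compound 3 to compound 4, 2.6-fold (0.42 log units) apart, within the scatter of two such steps. Going by these compounds alone, this shows no sign that the change behaves differently on the two cores, but it does not show that the change carries over unaltered, since there are only two steps and they differ in both the core and the place of the methyl, which lies three bonds along the chain from a carbonyl carbon in the earlier step.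

No amide chain shown here appears on both cores, so what the core alone contributes to the numbers in this assay stays open. Also open, from the compounds shown here alone, is how the series would respond to a branched chain, a cyclopropyl ring or a chain ending in an amine or a carboxylic acid in place of these straight chains.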